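Amide nitrogen substituent variation on the shared core

The source may hold more compounds than are shown below. What is called first, only, known or untested is meant among the compounds shown, and "the series" means these compounds.

Measured compounds in a functional assay on MDA-MB-231 cells (Homo sapiens) for inhibition, read by MTT assay, with a stated time of 48 h; on this read-out lower numbers stand for stronger inhibition and higher numbers for weaker inhibition:
- compound 1 `N#Cc1cccc(NC(=O)c2[nH]cnc2-c2nc3ccccc3[nH]2)c1`: 24900 nM
- compound 2 `O=C(NC1CC1)c1[nH]cnc1-c1nc2ccccc2[nH]1`: 35200 nM
- compound 3 `O=C(NC1CCC1)c1[nH]cnc1-c1nc2ccccc2[nH]1`: 33800 nM

Compound 3 holds the second highest of the three numbers. Its nearest neighbour is compound 2, with a 1.0-fold lower number from compound 2 to compound 3 (0.02 log units; within the scatter); its furthest is compound 1, with a 1.4-fold higher number from compound 1 to compound 3 (0.13 log units; within the scatter). The remaining pair gives a 1.4-fold higher number from compound 1 to compound 2 (0.15 log units; within the scatter). All three steps sit within the scatter, so the numbers shown do not separate the three substituents on the amide-type nitrogen.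

Compound 4 `O=C(NC1CCCCC1)c1[nH]cnc1-c1nc2ccccc2[nH]1` is not yet measured. It differs from compound 3 in one place: cyclohexyl in place of cyclobutyl on an amide-type nitrogen. The step that bears most directly on it is the ring enlargement from compound 2 to compound 3, which read a 1.0-fold lower number from compound 2 to compound 3 (0.02 log units; within the scatter); the two steps from the 3-cyanophenyl of compound 1 were likewise within the scatter. On these grounds the expected step of a 1.0-fold higher number from compound 3 to compound 4 (0.00 log units; within the scatter) is none beyond the scatter. Compound 4 is therefore estimated at 34000 nM in this assay, with a range of 15000 nM to 75000 nM.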

Compound 4, half-maximal inhibitory concentration: 8300 nM
Estimate against measurement, compound 4: 4.1-fold (0.61 log units) above, and the stated range ends above it.
By their numbers in this assay, from the lowest: compound 4; then compounds 1, 3 and 2 (each within the scatter of the next).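

In this assay the substituent on the amide-type nitrogen does separate compounds once cyclohexyl enters: the series gives a 4.1-fold lower number from compound 3 to compound 4 (0.61 log units; beyond the scatter) and a 4.2-fold lower number from compound 2 to compound 4 (0.63 log units; beyond the scatter) and also a 3.0-fold lower number from compound 1 to compound 4 (0.48 log units; beyond the scatter) and all three steps lie beyond the scatter, unlike every earlier step among 3-cyanophenyl, cyclopropyl and cyclobutyl. Ring size at this position is therefore not neutral across the whole range shown, since cyclopropyl to cyclobutyl gives no readable change while cyclobutyl to cyclohexyl does, leaving compound 4 with the lowest number of the four. Nothing measured here accounts for this difference.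

The compounds shown leave open where cyclopentyl or cycloheptyl would fall on this nitrogen. They also leave open whether an open hexyl chain or a piperidin-4-yl group would match cyclohexyl.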